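Cytotoxicity of a nitrophenyl compound, estimated from sparse data

A few compounds are considered here, and "the series" means these few. Any claim that something is new, unique, unknown or untested is made for them only; others in the source may bear on it.

Measured so far in a toxicity assay on cells (Macrophage, Mus musculus, strain BALB/c) for cytotoxicity, read by MTT assay; a higher number here means a weaker inhibitor, a lower number a stronger inhibitor:
- compound 1 `C=CCOc1cc(OC)c(C(=O)/C=C/Cc2ccccc2)c(OCC=C)c1`: 14800 nM
- compound 2 `C=CCOc1cc(OC)c(C(=O)/C=C/c2ccncc2)c(OCC=C)c1`: "not determined" (no result reported)

Among the compounds with values here, only one number exists so far. Compound 2 has no place on the scale, as its entry reads "not determined" (no result reported), so it offers no starting value to build on. The compound of interest is compound 3 `C=CCOc1cc(OC)c(C(=O)/C=C/c2ccc([N+](=O)[O-])cc2)c(OCC=C)c1`, which has yet to be measured. The structural change is 4-nitrophenyl in place of pyridin-4-yl on a double-bonded chain carbon bound to a double-bonded chain carbon.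

Within the data shown here, no measured step shows what such a swap does in this assay. Among the measured compounds shown here, the expectation is therefore no shift beyond the usual scatter from the sole guide, compound 1 at 14800 nM, and no direction can be favoured. For compound 3 the expected value is 15000 nM, with an estimated range from 5000 nM to 45000 nM.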

Compound 3, half-maximal inhibitory concentration: 13200 nM
Compound 3: middle estimate off by 1.1-fold (0.06 log units), on the high side; measured number inside the range.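

In this assay, the step reads a 1.1-fold lower number from compound 1 to compound 3 (0.05 log units; within the scatter), so 4-nitrophenyl and benzyl at this place, on a double-bonded chain carbon bound to a double-bonded chain carbon, give readings that cannot be told apart, even though the two groups differ in their atoms. The swap from pyridin-4-yl to 4-nitrophenyl itself cannot be read, as compound 2 has no number to set against compound 3. Nothing measured here explains why compound 1 and compound 3 read alike.

Two groups at one place say little about how far this sameness extends, so an amine, a carboxylic acid or a longer chain there could still read differently. The compounds shown also leave open whether any change to the rest of the shared core would move the number.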